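A few compounds are considered here, and "the series" means these few. Any claim that something is new, unique, unknown or untested is made for them only; others in the source may bear on it.

Series notes, C-X-C chemokine receptor type 4 binding. The three measured compounds share one core, a benzylic diamine bridge carrying an arylsulfonamide on one side and an aryl amide on the other. In an assay on MDA-MB-231 cells for displacement of a labelled ligand from C-X-C chemokine receptor type 4 (Homo sapiens), read by fluorescence and microscopy, with stated times of 10 min and 30 min (on this read-out higher numbers stand for an effect only at larger amounts of compound and lower numbers for an effect already at smaller amounts), compound 1, `COc1ccccc1C(=O)NCc1ccc(CNS(=O)(=O)c2cccc3ccccc23)cc1`, gives only a limit, > 1000 nM. Compound 2, `Cc1cccc(S(=O)(=O)NCc2ccc(CNC(=O)c3ccccc3C)cc2)c1`, gives 1000 nM in this assay. Compound 3, `O=C(NCc1ccc(CNS(=O)(=O)c2cccc3ccccc23)cc1)c1cccnc1`, gives 1000 nM in this assay, level with compound 2 at the digits printed and within the scatter of it. For the measured compounds named here, the one measured step that touches the carbonyl carbon, a number no higher from compound 1 to compound 3 (the limit leaves the size open), cannot be sized, because the limit of > 1000 nM in this assay, at which 1 of the 3 values shown sits, is where the value of compound 1 sits.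

Compound 4, `Cc1ccccc1C(=O)NCc1ccc(CNS(=O)(=O)c2cccc3ccccc23)cc1`, is the next member. It differs from compound 3 by 2-methylphenyl in place of pyridin-3-yl on a carbonyl carbon. Going by the values given here, the step bearing on this position is the one from compound 1 to compound 3, and its size is open. Compound 2 carries the same 2-methylphenyl on its carbonyl carbon and differs from compound 4 only on the sulfonyl side; its value and that of compound 3 agree within the scatter. No step beyond the scatter is therefore expected; the step of no change at the digits printed from compound 3 to compound 4 (within the scatter) is estimated as flat. Compound 4 is expected to give 1000 nM in this assay, within the range 400 nM to 3000 nM, with a real chance that only a limit is recorded.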

Compound 4, effective concentration (reported as EC, without a stated level of effect): 100 nM
Estimate against measurement, compound 4: 10-fold (1.00 log units) above; measured number outside the range, below it.
By their numbers in this assay, from the lowest: compound 4; then compounds 2 and 3 (each within the scatter of the next).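

For the compounds shown here, on the carbonyl carbon, 2-methylphenyl in place of pyridin-3-yl gives the first step at this position that can be sized in this assay, with a 10-fold lower number from compound 3 to compound 4 (1.00 log units; beyond the scatter) as its reading. Methyl in place of methoxy on an aromatic carbon also counts here, with an at least 10-fold lower number from compound 1 to compound 4 (1.00 log units; beyond the scatter) as its reading, and that step starts from a limit on compound 1: the limit of > 1000 nM in this assay, at which 1 of the 4 values shown sits. The sulfonyl side matters as well: with 2-methylphenyl held on the carbonyl carbon, naphthalen-1-yl in place of 3-methylphenyl gives a 10-fold lower number from compound 2 to compound 4 (1.00 log units; beyond the scatter) as its reading, so among the compounds shown only the one carrying both of these groups stands apart.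

On these data alone, what a plain phenyl on the carbonyl carbon would give stays open, and the step at this position cannot yet be divided between the methyl entering and the ring nitrogen leaving. Also open, as far as these compounds go, is whether an amine or a carboxylic acid on that phenyl, or a longer chain in place of the methyl, would leave compound 4 at 100 nM or move the number in either direction.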